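A few compounds are considered here, and "the series" means these few. Any claim that something is new, unique, unknown or untested is made for them only; others in the source may bear on it.

Working notes on the series. The shared core of compound 2 `CC(C)=CCC1Cc2c(OCCCNC(=O)c3cccs3)cc(=O)n(CCCO)c2CC1(C)C` carries a chain ending in a thiophene amide; in a functional assay on PANC-1 cells (Homo sapiens) for inhibition, read by MTT assay, with a stated time of 24 h, tested at 10 uM (on this read-out lower numbers stand for less inhibition and higher numbers for more inhibition at the one concentration tested (going by the name of the read-out)), compound 2 gives 33.6%, the lowest of the three numbers. Compound 1 `CC(C)=CCC1Cc2c(OCCCNS(=O)(=O)c3ccc([N+](=O)[O-])cc3)cc(=O)n(CCCO)c2CC1(C)C` gives 47.7% and compound 3 `CC(C)=CCC1Cc2c(OCCCOc3ccc([N+](=O)[O-])cc3)cc(=O)n(CCCO)c2CC1(C)C` gives 47.5%. Both measured steps change only the group at the end of that chain: a number 14.1 percentage points lower from compound 1 to compound 2 (beyond the scatter), and a number 13.9 percentage points higher from compound 2 to compound 3 (beyond the scatter). Compound 4 `CC(C)=CCC1Cc2c(OC(=O)Nc3ccc(F)cc3F)cc(=O)n(CCCO)c2CC1(C)C` goes further, with (2,4-difluorophenyl)carbamoyl in place of 3-(((thiophen-2-yl)carbonyl)amino)propyl on an oxygen on an aromatic ring, so the chain itself is gone. Neither step tests that, but both show the end group shifting this assay by a modest amount, and both other end groups sit higher than compound 2. A modest rise is therefore expected, a number 9.4 percentage points higher from compound 2 to compound 4 (within the scatter). For compound 4 the estimate is 43%, within 25% to 60%.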

Compound 4, a percentage reported as inhibition, at one concentration (the size of the read-out at that concentration, not a potency): 69.7%
Compound 4: the middle estimate sits 26.7 percentage points below what was measured; measured number above the stated range.
By their numbers in this assay, from the lowest: compound 2; then compounds 3 and 1 (each within the scatter of the next); then compound 4.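

Going by these compounds alone, the largest step so far, a number 36.1 percentage points higher from compound 2 to compound 4 (beyond the scatter) in this assay, comes from replacing the whole chain on the oxygen on an aromatic ring, not only its end group. This position therefore accepts (2,4-difluorophenyl)carbamoyl without the propyl chain, and the change reaches further than either end-group swap. No measurement is available to explain the size of this step.

The change replaces chain and end group together, so the contribution of each remains unseparated. As far as these compounds go, whether a carbamoyl bearing an unsubstituted phenyl or a thiophene would behave the same remains open.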